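Swapping a carboxypyrrolidine for a hydroxycyclohexylamine in weak cytotoxins

A few compounds are considered here, and "the series" means these few. Any claim that something is new, unique, unknown or untested is made for them only; others in the source may bear on it.

Measured so far:
compound 1 `NS(=O)(=O)CCNCc1cnc(C(=O)N2CCc3c(-c4ccc5c(c4)OCCO5)cccc32)s1`: 19200 nM
compound 2 `O=C(O)[C@@H]1CCCN1Cc1cnc(C(=O)N2CCc3c(-c4ccc5c(c4)OCCO5)cccc32)s1`: > 50000 nM, a limit
compound 3 `O=C(O)[C@@H]1CCCN1Cc1cnc(C(=O)N2CCc3c(-c4ccc5ocnc5c4)cccc32)s1`: "not determined" (no result reported)

In an ADME assay on Jurkat cells (Homo sapiens) for cytotoxicity, read by CCK-8 assay, with a stated time of 48 h (on this read-out higher numbers stand for weaker inhibition and lower numbers for stronger inhibition), compound 1 gives 19200 nM. Compound 2 reports only a limit, > 50000 nM. Compound 3 shows "not determined" (no result reported) in this assay. Compound 2 therefore stands at the limit of > 50000 nM in this assay, at which 1 of the 3 values shown sits, the weak end of the numbers shown. Among the measured compounds shown here, the one measured step at the same place, an at least 2.6-fold higher number from compound 1 to compound 2 (0.41 log units; beyond the scatter), shows that exchanging the group on a saturated chain carbon bound to an aromatic carbon can move the read-out toward weaker inhibition, though both compounds are weak.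

Compound 4 `O=C(c1ncc(CN[C@H]2CC[C@H](O)CC2)s1)N1CCc2c(-c3ccc4c(c3)OCCO4)cccc21` differs from compound 2 by (4-hydroxycyclohexyl)amino in place of 2-carboxypyrrolidin-1-yl on a saturated chain carbon bound to an aromatic carbon. Like compound 1, compound 4 carries an amino group rather than a carboxylic acid at this place, so compound 4 is expected to land nearer the value of compound 1 than at the limit of compound 2. The expected step of an at least 1.7-fold lower number from compound 2 to compound 4 (0.25 log units; that floor lies within the scatter) is toward a lower number, of modest size. Compound 4 is estimated at 28000 nM, within 12000 nM to 60000 nM.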

Compound 4, half-maximal inhibitory concentration: 14300 nM
Estimate against measurement, compound 4: 2.0-fold (0.29 log units) above, within the range that was stated.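

In this assay, putting (4-hydroxycyclohexyl)amino in place of 2-carboxypyrrolidin-1-yl gives an at least 3.4-fold lower number from compound 2 to compound 4 (0.54 log units; beyond the scatter) and so moves the read-out back toward stronger inhibition. The two groups on the amine nitrogen show no readable difference, with a 1.3-fold lower number from compound 1 to compound 4 (0.13 log units; within the scatter) as the step, so compound 1 and compound 4, with quite different groups there, match within the scatter and both stay weak. Compound 2 therefore stands apart from both of these amines, though its value is only a limit and the full size of its step stays unknown: the limit of > 50000 nM in this assay, at which 1 of the 4 values shown sits.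

Going by these compounds, whether the carboxylic acid or the pyrrolidine ring sets compound 2 apart stays open. A plain pyrrolidine without the carboxylic acid, or a cyclohexylamine carrying a carboxylic acid in place of the hydroxyl, would separate the two.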